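Swapping a pyridine for a quinoline on the amide

A few compounds are considered here, and "the series" means these few. Any claim that something is new, unique, unknown or untested is made for them only; others in the source may bear on it.

Measured so far:
compound 1 `COc1ccc(Cl)cc1C(=O)NCCC1CCN(S(=O)(=O)NC(=O)NC[C@@H]2C[C@@H]3CC[C@@H]2O3)CC1` — 30%
compound 2 `O=C(NC1CCCCC1)NS(=O)(=O)N1CCC(CCNC(=O)C(F)(F)F)CC1` — 13%
compound 3 `Cc1cccc(C(=O)NCCC2CCN(S(=O)(=O)NC(=O)NC[C@@H]3C[C@@H]4C=C[C@@H]3C4)CC2)n1` — 20%

In a functional assay on the whole organism (blood) with Rattus norvegicus as the target, with stated times of 24 h and 1 h, at a dose of 5 mg/kg by the intraperitoneal route (a lower number here means a weaker effect, a higher number a stronger effect of the compound at the dose given), compound 3 gives a value that sits between those of compound 1 and compound 2, yet both gaps lie within the usual scatter, so the three compounds cannot be told apart on these numbers. Compound 4 `COc1ccc2nccc(C(=O)NCCC3CCN(S(=O)(=O)NC(=O)NC[C@@H]4C[C@@H]5C=C[C@@H]4C5)CC3)c2c1` has not been measured; it differs from compound 3 in one place: 6-methoxyquinolin-4-yl in place of 6-methylpyridin-2-yl on a carbonyl carbon. Among the measured compounds shown here, no measured pair shows what such a change does here, so there is nothing to anchor the size or direction of the step. On that basis compound 4 is expected to give 25% in this assay, within 10% to 45%, meaning an estimated step of a number 5 percentage points higher from compound 3 to compound 4 (within the scatter) that is not expected to exceed the scatter.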

Compound 4, a percentage reported as activity, at one dose (the size of the read-out at that dose, not a potency): 10%
The estimate for compound 4 lay 15 percentage points above the measured number; low and high end bracket the measured number.
By their numbers in this assay, from the lowest: compounds 4, 2, 3 and 1 (each within the scatter of the next, the first and the last beyond it).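

Among the compounds shown here, this is the first pair that isolates a change at this position. In this assay, for the compounds shown here, placing 6-methoxyquinolin-4-yl instead of 6-methylpyridin-2-yl on the carbonyl carbon gives a number 10 percentage points lower from compound 3 to compound 4 (within the scatter), so even this larger two-ring group produces no step that can be told from the scatter. No measurement shown offers a reason for this result.

The compounds shown leave open how a plain quinolin-4-yl group would compare with 6-methoxyquinolin-4-yl. They also leave open what a non-aromatic group, such as a butyl chain or a carboxylic acid, would do on this carbonyl carbon.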